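Replacing the benzylamino link in compound 2 with a phenoxy link

The source may report more compounds than this note shows. Statements on the series, on what has been measured and on what is new or still open speak of the compounds shown alone.

Compound 2 `Nc1cc(N)c2nc(-c3ccccc3)c(NCc3ccc(F)cc3)nc2c1` stands lowest of the three compounds measured in a functional assay on NCI-H23 cells (Homo sapiens) for inhibition, read by sulforhodamine B assay, with a stated time of 48 h (on this read-out higher numbers stand for weaker inhibition of growth and lower numbers for stronger inhibition of growth), where compound 2 gives 2400 nM. Compound 1 `COc1ccc(CNc2nc3cc(N)cc(N)c3nc2-c2ccccc2)cc1OC` gives 17000 nM and compound 3 `COc1ccc(CNc2nc3cc(N)cc(N)c3nc2-c2ccccc2)cc1` gives 17000 nM, so the two steps reaching compound 2, a 7.1-fold lower number from compound 1 to compound 2 (0.85 log units; beyond the scatter) and a 7.1-fold higher number from compound 2 to compound 3 (0.85 log units; beyond the scatter), are modest and beyond the scatter, while no change at the digits printed from compound 1 to compound 3 (within the scatter).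

Compound 4 `Nc1cc(N)c2nc(-c3ccccc3)c(Oc3ccc(F)cc3)nc2c1` differs from compound 2 by 4-fluorophenoxy in place of (4-fluorobenzyl)amino on an aromatic carbon. Within the data shown here, none of the measured steps touches this link: all three concern only the substituent on the pendant ring and keep the benzylamino connection intact, so they give no direct guide to the change. Among the measured compounds shown here, with the hydrogen-bond donor and the saturated chain carbon both removed, and no comparable precedent among the measured compounds, a modest step toward a higher number is expected, namely a 2.5-fold higher number from compound 2 to compound 4 (0.40 log units; beyond the scatter), though the range is wide. Compound 4 is therefore estimated at 6000 nM, between 1500 nM and 25000 nM.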

Compound 4, concentration for 50% growth inhibition: 20900 nM
The estimate for compound 4 lay 3.5-fold (0.54 log units) below the measured number; the measured number falls inside the stated range.
By their numbers in this assay, from the lowest: compound 2; then compounds 1, 3 and 4 (each within the scatter of the next).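

In this assay, the connection at this position, next to the ring nitrogen, proves to matter: 4-fluorophenoxy in place of (4-fluorobenzyl)amino gives an 8.7-fold higher number from compound 2 to compound 4 (0.94 log units; beyond the scatter). The earlier steps shown here changed only the substituents on the pendant ring while keeping the benzylamino connection, whereas this step shows that the number also moves with the link when the 4-fluorophenyl group stays in place. No measurement offered here accounts for the size of this step.

The change removes the saturated chain carbon and replaces the nitrogen with oxygen in a single step, so the compounds shown cannot separate these two contributions. A 4-fluoroanilino group, which keeps the nitrogen without the chain carbon, and a 4-fluorobenzyloxy group, which keeps the chain carbon with oxygen, would address that question.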